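The source may report more compounds than this note shows. Statements on the series, on what has been measured and on what is new or still open speak of the compounds shown alone.

Of the compounds shown here, two of a shared core have been measured in an assay on isolated protein for binding affinity to adenosine receptor A3 (Homo sapiens); a lower number here means a stronger inhibitor, a higher number a weaker inhibitor. Compound 1 `CNC(=O)[C@H]1O[C@@H](n2cnc3c(NCc4cc(Cl)cc(Cl)c4)ncnc32)[C@H](O)[C@@H]1O` gives 2.5 nM in this assay. Compound 2 `CNC(=O)[C@H]1O[C@@H](n2cnc3c(NCc4cc(Cl)cc(Cl)c4)ncnc32)[C@H](O)[C@@H]1N` gives 25 nM in this assay; the only difference is amino in place of hydroxy on a saturated ring carbon, and the step of a 10-fold higher number from compound 1 to compound 2 (1.00 log units; beyond the scatter). Among the compounds with values here, compound 2 thus stands highest of the two numbers known, with compound 1 as its only neighbour.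

Compound 3 `CNC(=O)[C@H]1O[C@@H](n2cnc3c(NCc4cc(Cl)ccc4OC)ncnc32)[C@H](O)[C@@H]1N` keeps the amino group of compound 2 and differs from it in the aryl part: 5-chloro-2-methoxyphenyl in place of 3,5-dichlorophenyl on a saturated chain carbon bound to a nitrogen on an aromatic ring. Within the data shown here, no measured step bears on this change; the one step that is known runs between the hydroxy and amino groups on the ring carbon, a different place, so it says nothing about exchanging one substituted phenyl for another. The expectation for compound 3 therefore rests on compound 2 alone, with a wide range, and the step of a 2.4-fold higher number from compound 2 to compound 3 (0.38 log units; beyond the scatter) is estimated to be small relative to the uncertainty. Compound 3 is expected to give 60 nM in this assay, within 12 nM to 300 nM.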

Compound 3, inhibition constant: 15 nM
Compound 3: middle estimate off by 4.0-fold (0.60 log units), on the high side; the measured number falls inside the stated range.
By their numbers in this assay, from the lowest: compound 1; then compounds 3 and 2 (each within the scatter of the next).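

In this assay, 5-chloro-2-methoxyphenyl in place of 3,5-dichlorophenyl on a saturated chain carbon bound to a nitrogen on an aromatic ring gives a 1.7-fold lower number from compound 2 to compound 3 (0.22 log units; within the scatter), so with the amino group kept on the ring carbon, the two aryl groups cannot be told apart in this assay. The earlier compounds shown here all carried 3,5-dichlorophenyl and so gave no reading at this position; the pair now shows that a group with 1 chlorine and 1 hydrogen-bond acceptor reads alike with one that has 2 chlorines and no hydrogen-bond acceptor. No measurement at hand accounts for this likeness.

The compounds shown leave open whether the step of a 10-fold higher number from compound 1 to compound 2 (1.00 log units; beyond the scatter) would hold with 5-chloro-2-methoxyphenyl in place of 3,5-dichlorophenyl, since only one aryl group has been read with both the hydroxy and the amino group. They also leave open how far this position tolerates other groups, such as a pyridine ring, a carboxylic acid on the phenyl ring or a longer chain in place of the benzyl link.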